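Chloro Added to the Phenoxy Ring of Compound 1

The source may hold more compounds than are shown below. What is called first, only, known or untested is meant among the compounds shown, and "the series" means these compounds.

In an assay on isolated protein for inhibition of Fatty-acid amide hydrolase 1 (Homo sapiens), read by fluorescence (a lower number here means a stronger inhibitor, a higher number a weaker inhibitor), compound 1 `O=C(Oc1ccc([N+](=O)[O-])cc1)N1CCN(S(=O)(=O)c2ccc(Oc3ccccc3)cc2)CC1` gives 322 nM while compound 2 `O=C(Oc1ccc([N+](=O)[O-])cc1)N1CCN(S(=O)(=O)c2ccc(-c3ccc(Cl)c(Cl)c3)cc2)CC1` gives 382 nM and the step of a 1.2-fold higher number from compound 1 to compound 2 (0.07 log units; within the scatter) lies within the scatter, so neither stands apart. Compound 3 `O=C(Oc1ccc([N+](=O)[O-])cc1)N1CCN(S(=O)(=O)c2ccc(Oc3cccc(Cl)c3)cc2)CC1` differs from compound 1 by chloro in place of hydrogen on an aromatic carbon on the phenoxy ring. Among the measured compounds shown here, no measured step adds a chloro to this ring; the only known step of a 1.2-fold higher number from compound 1 to compound 2 (0.07 log units; within the scatter) replaced the whole phenoxy group and moved little, so no change beyond the scatter in this assay is expected. Compound 3 is estimated at 260 nM within 100 nM to 700 nM giving an expected step of a 1.2-fold lower number from compound 1 to compound 3 (0.09 log units; within the scatter) from compound 1.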

Compound 3, half-maximal inhibitory concentration: 380 nM
Estimate against measurement, compound 3: 1.5-fold (0.16 log units) below, within the range that was stated.
By their numbers in this assay, from the lowest: compounds 1, 3 and 2 (each within the scatter of the next).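

In this assay a chloro placed on the phenoxy ring itself gives a 1.2-fold higher number from compound 1 to compound 3 (0.07 log units; within the scatter) and so stays within the scatter, which the earlier swap of the whole group could not show. Exchanging the 3,4-dichlorophenyl for 3-chlorophenoxy gives a 1.0-fold lower number from compound 2 to compound 3 (0.00 log units; within the scatter) and is also within the scatter, so these three end groups cannot be told apart here. No outside measurement bears on why this position responds so little.

On these data alone, whether an amine or a carboxylic acid at this position would shift the number remains open. So does whether a longer chain there would shift it.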